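The source may hold more compounds than are shown below. What is called first, only, known or untested is meant among the compounds shown, and "the series" means these compounds.

Measured so far in an assay on liver for inhibition of sterol O-acyltransferase 1 (Rattus norvegicus), using microsomes; a lower number here means a stronger inhibitor, a higher number a weaker inhibitor:
compound 1, `CC(C)c1cccc(C(C)C)c1OC(=O)NS(=O)(=O)Oc1c(C(C)C)cc(O)cc1C(C)C`: > 50000 nM
compound 2, `CC(C)c1cc(C(C)(C)C)cc(C(C)C)c1OC(=O)NS(=O)(=O)Oc1c(C(C)C)cccc1C(C)C`: 8800 nM
compound 3, `CC(C)c1cc([N+](=O)[O-])cc(C(C)C)c1OC(=O)NS(=O)(=O)Oc1c(C(C)C)cccc1C(C)C`: > 50000 nM

The value given for compound 1 is a limit of the assay, not a number. The value given for compound 3 is likewise a limit of the assay. Only compound 2 has a number in this assay. Compound 3 thus stands at the weak end of what this assay reports, one of two values sitting there (the limit of > 50000 nM in this assay, at which 2 of the 3 values shown sit). Among the measured compounds shown here, the one measured step that reaches compound 3 is an at least 5.6-fold higher number from compound 2 to compound 3 (0.75 log units; beyond the scatter), which lies beyond the scatter; its true size is known only as a bound.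

Compound 4, `CC(C)c1cc(Cl)cc(C(C)C)c1OC(=O)NS(=O)(=O)Oc1c(C(C)C)cccc1C(C)C`, is not yet measured. It differs from compound 3 by chloro in place of nitro on an aromatic carbon. For the measured compounds named here, no measured step swaps nitro for chloro. Going by the values given here, the only step bearing on this position is the tert-butyl to nitro step above, which starts from compound 2 at 8800 nM. Chloro is neither of those groups, so the expectation is set between the two outcomes, with a real chance that this assay again reports only a limit. Compound 4 in this assay is expected near 20000 nM (7000 nM to 60000 nM). That estimate amounts to an expected step of an at least 2.5-fold lower number from compound 3 to compound 4 (0.39 log units; beyond the scatter).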

Compound 4, half-maximal inhibitory concentration: 42000 nM
The estimate for compound 4 lay 2.1-fold (0.32 log units) below the measured number, and the stated range covers the measured number.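

In this assay, compound 4 returns a number rather than a limit, so a group other than tert-butyl at this position, meta to two isopropyl groups, can still give a readable result. Chloro in place of tert-butyl gives a 4.8-fold higher number from compound 2 to compound 4 (0.68 log units; beyond the scatter), so the loss seen on replacing tert-butyl is not particular to nitro: both replacements move the number up beyond the scatter, and compound 2 remains the only compound of the three with this position variation that holds tert-butyl. Chloro in place of nitro gives an at least 1.1-fold lower number from compound 3 to compound 4 (0.07 log units; that floor lies within the scatter), and this step cannot be sized because the nitro value is a limit of the assay and not a number: the limit of > 50000 nM in this assay, at which 2 of the 4 values shown sit.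

Three groups at this position do not settle which feature of tert-butyl goes with the lower number, or whether any group here can improve on it. Going by these compounds, how an amine, a methoxy group or a longer alkyl chain at this position would compare with tert-butyl and chloro remains open.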